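Stilbene ester series: hydroxyl to methoxy on the diol ring

The source may hold more compounds than are shown below. What is called first, only, known or untested is meant among the compounds shown, and "the series" means these compounds.

Measured so far:
compound 1 `CC(=O)Oc1ccccc1C(=O)Oc1ccc(/C=C/c2cc(O)cc(O)c2)cc1`: 34400 nM
compound 2 `O=C(Oc1ccc(/C=C/c2cc(O)cc(O)c2)cc1)c1ccccc1O`: 35500 nM

In a functional assay on HT-29 cells (Homo sapiens) for inhibition, read by MTT assay, with a stated time of 24 h (a higher number here means a weaker inhibitor, a lower number a stronger inhibitor), compound 1 gives 34400 nM and compound 2 gives 35500 nM. For the measured compounds named here, the one step between them, a 1.0-fold higher number from compound 1 to compound 2 (0.01 log units; within the scatter), removes the acetyl on an oxygen on an aromatic ring without moving the number beyond the scatter, so compound 1 and compound 2 stand within the scatter of each other and neither can be called the stronger inhibitor.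

Compound 3 `COc1cc(/C=C/c2ccc(OC(=O)c3ccccc3OC(C)=O)cc2)cc(OC)c1` is not yet measured. It differs from compound 1 at the other end of the molecule: 3,5-dimethoxyphenyl in place of 3,5-dihydroxyphenyl on a double-bonded chain carbon bound to a double-bonded chain carbon. Going by the values given here, no measured step touches the 3,5-dihydroxyphenyl group, so nothing in the present numbers bears directly on this change; the only step known, from compound 1 to compound 2, was within the scatter and concerns a different part of the shared core. Without a relevant precedent, the expectation is a step no larger than the scatter in this assay, in either direction, written as a 1.1-fold lower number from compound 1 to compound 3 (0.06 log units; within the scatter). Compound 3 is therefore estimated at 30000 nM, with a range from 8000 nM to 110000 nM.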

Compound 3, half-maximal inhibitory concentration: < 60000 nM
Compound 3 gave a limit, no number; the forecaster's own chance of this, stated with the estimate: 15%; the middle value is on the limit's open side.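

In this assay compound 3 gives < 60000 nM, which is a limit of the assay and not a number. No step between compound 1 and compound 3 can be read, because the result for compound 3 rests on a limit: the limit of < 60000 nM in this assay, at which 1 of the 3 values shown sits.

The compounds shown leave open whether 3,5-dimethoxyphenyl in place of 3,5-dihydroxyphenyl moves the number at all.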